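Replacing a branched chain with 1-fluoroethenyl on the carbonyl

The source may report more compounds than this note shows. Statements on the series, on what has been measured and on what is new or still open speak of the compounds shown alone.

Three compounds have been measured so far in a functional assay on A549 cells (Homo sapiens) for antiproliferative activity, read by MTT assay, with a stated time of 72 h (on this read-out higher numbers stand for weaker inhibition and lower numbers for stronger inhibition), with these results

compound 1 `C=CC(=O)Nc1cccc(Oc2nc(Nc3cccc(OC)c3)nc3c2CSCC3)c1` gives 10100 nM
compound 2 `CCC/C=C/C(=O)Nc1cccc(Oc2nc(Nc3cccc(OC)c3)nc3c2CSCC3)c1` gives 11800 nM
compound 3 `COc1cccc(Nc2nc3c(c(Oc4cccc(NC(=O)/C=C/C(C)C)c4)n2)CSCC3)c1` gives 25300 nM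

Compound 3 has the highest number of the three at 25300 nM, and its gaps to both others lie beyond the scatter. The next structure is compound 4 `C=C(F)C(=O)Nc1cccc(Oc2nc(Nc3cccc(OC)c3)nc3c2CSCC3)c1`, which differs from compound 3 on a carbonyl carbon, where 1-fluoroethenyl takes the place of 3-methylbut-1-en-1-yl (1-fluoroethenyl in place of 3-methylbut-1-en-1-yl on a carbonyl carbon).

The closest evidence is a 2.5-fold higher number from compound 1 to compound 3 (0.40 log units; beyond the scatter), where the same 3-methylbut-1-en-1-yl group replaces vinyl. Two further steps give context. The unbranched chain stays within the scatter in a 1.2-fold higher number from compound 1 to compound 2 (0.07 log units; within the scatter), while the branched chain gives a modest rise in a 2.1-fold higher number from compound 2 to compound 3 (0.33 log units; beyond the scatter). Among the compounds with values here, no measured compound carries 1-fluoroethenyl, so how it compares with vinyl remains open. Compound 4 is therefore expected to fall near compound 1 at 10100 nM, reversing most of that modest rise in this assay. For compound 4 the expected change is a 2.5-fold lower number from compound 3 to compound 4 (0.40 log units; beyond the scatter), toward a lower number. Compound 4 is estimated at 10000 nM, with an expected range from 3500 nM to 28000 nM.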

Compound 4, half-maximal inhibitory concentration: 29600 nM
Estimate against measurement, compound 4: 3.0-fold (0.47 log units) below; measured number above the stated range.
By their numbers in this assay, from the lowest: compounds 1 and 2 (each within the scatter of the next); then compounds 3 and 4 (each within the scatter of the next).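

At this position on the carbonyl carbon, 1-fluoroethenyl and 3-methylbut-1-en-1-yl cannot be told apart in this assay (a 1.2-fold higher number from compound 3 to compound 4 (0.07 log units; within the scatter)), so a group of 3 heavy atoms reads the same here as one of 5 heavy atoms. The change of fluoro in place of hydrogen on the double-bonded chain carbon bound to the carbonyl carbon gives a modest rise (a 2.9-fold higher number from compound 1 to compound 4 (0.47 log units; beyond the scatter)), and the gap to the unbranched chain is of similar size (a 2.5-fold higher number from compound 2 to compound 4 (0.40 log units; beyond the scatter)), which shows that a branched chain is not required for a number in this higher range and that chain size alone does not order these four compounds, since the small 1-fluoroethenyl group groups with the larger branched chain of compound 3 and not with vinyl in compound 1. Nothing available here accounts for why a single fluoro moves the number this way.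

Going by these compounds, whether this rise belongs to fluoro itself or would also come with chloro or a methyl group on the same chain carbon remains open. Also open, on these data alone, is how a saturated chain such as ethyl on the carbonyl carbon would compare with vinyl in this assay, and whether the fluoro step would hold on a longer chain such as pent-1-en-1-yl.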